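The compounds below may be only part of what the source reports. "The series", "measured", "known", "first", "only" and "open" are said of these compounds alone.

Working notes on the series

The shared core of compound 1 `COc1ccc(-c2c(S(=O)(=O)c3cccc(F)c3)cnc3c(F)cccc23)cc1` carries a 4-methoxyphenyl group; in an ADME assay on microsomes from liver (Homo sapiens) for metabolic stability, tested at 2.5 uM (on this read-out higher numbers stand for fast clearance and lower numbers for slow clearance), compound 1 gives 2.48 mL/min. Compound 2 `COc1cccc(-c2c(S(=O)(=O)c3cccc(F)c3)cnc3c(F)cccc23)c1` carries 3-methoxyphenyl in place of 4-methoxyphenyl on an aromatic carbon, and in this assay compound 2 gives 2.6 mL/min. Within the data shown here, compound 2 has the highest of the two numbers so far, though the only step, a 1.0-fold higher number from compound 1 to compound 2 (0.02 log units; within the scatter), is within the scatter, so the two compounds cannot be told apart on this read-out.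

Compound 3 `O=S(=O)(c1cccc(F)c1)c1cnc2c(F)cccc2c1-c1ccc(F)cc1` differs from compound 2 by 4-fluorophenyl in place of 3-methoxyphenyl on an aromatic carbon. Among the measured compounds shown here, only the step from compound 1 to compound 2 bears on it, and that step was flat, so no basis exists for expecting a shift beyond the scatter in this assay. The estimated step is a 1.1-fold lower number from compound 2 to compound 3 (0.05 log units; within the scatter). For compound 3 the expected value in this assay is 2.3 mL/min, within the range 1.2 mL/min to 4.5 mL/min.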

Compound 3, intrinsic clearance in a liver preparation (reported as CLH), per the amount of preparation that the assay uses: 0.19 mL/min
For compound 3 the middle estimate is 12-fold (1.08 log units) above the measured one; the whole stated range lies above it.
By their numbers in this assay, from the lowest: compound 3; then compounds 1 and 2 (each within the scatter of the next).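

This position on the shared core responds strongly to the choice of group in this assay: compound 1 and compound 2 lie within the scatter of each other, yet 4-fluorophenyl in place of 3-methoxyphenyl gives a 14-fold lower number from compound 2 to compound 3 (1.14 log units; beyond the scatter) on the same read-out. Fluoro in place of methoxy gives a 13-fold lower number from compound 1 to compound 3 (1.12 log units; beyond the scatter), so among these three compounds the read-out separates methoxy from fluoro, not 3-methoxyphenyl from 4-methoxyphenyl. Nothing measured here bears on what lies behind these steps.

From the compounds shown here alone, whether plain phenyl or 4-chlorophenyl would fall with compound 3 or with compound 1 and compound 2 remains open. Also open, going by these compounds, is whether 3-fluorophenyl would match 4-fluorophenyl, which would show if the placement of fluoro matters here.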